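This account rests on a few compounds, and the source may have more. Where it says the series, first, only, none or still open, it means among the compounds named here.

Compound 1, with the structure `O=C1Nc2ccccc2C1(c1c[nH]c2ccccc12)c1c[nH]c2ccccc12`, is the simplest member of this small set. In a functional assay on MCF7 cells (Homo sapiens) for cytotoxicity, read by MTT assay, with a stated time of 48 h (on this read-out lower numbers stand for stronger inhibition and higher numbers for weaker inhibition), compound 1 gives 49800 nM. Compound 3, with the structure `O=C1Nc2ccc(F)cc2C1(c1c[nH]c2ccccc12)c1c[nH]c2ccccc12`, differs from it by a single change, (fluoro in place of hydrogen on an aromatic carbon), and in this assay compound 3 gives 23600 nM, so the change made the step of a 2.1-fold lower number from compound 1 to compound 3 (0.32 log units; beyond the scatter). Compound 2, with the structure `COc1cccc2[nH]cc(C3(c4c[nH]c5cccc(OC)c45)C(=O)Nc4ccccc43)c12`, carries a different core, and the difference between the two cores is not broken down here. In this assay, within the data shown here, compound 2 gives 14100 nM, the lowest of the three numbers so far. Compound 4, with the structure `COc1cccc2[nH]cc(C3(c4c[nH]c5cccc(OC)c45)C(=O)Nc4ccc(F)cc43)c12`, is not yet measured. It differs from compound 2 by fluoro in place of hydrogen on an aromatic carbon, the same change as the one made on the core of compound 1, and at the same place. Among the measured compounds shown here, a step of about a 2.0-fold lower number from compound 2 to compound 4 (0.30 log units; within the scatter) is expected, because the only guide is the step of a 2.1-fold lower number from compound 1 to compound 3 (0.32 log units; beyond the scatter) and nothing suggests the new core would respond differently. Compound 4 is therefore expected to give about 7000 nM in this assay, most likely between 3500 nM and 14000 nM.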

Compound 4, half-maximal inhibitory concentration: 7500 nM
Beside the measured number, compound 4's estimate is 1.1-fold (0.03 log units) below it; the measured number falls inside the stated range.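

In this assay, fluoro in place of hydrogen on an aromatic carbon gives a 1.9-fold lower number from compound 2 to compound 4 (0.27 log units; within the scatter), and this step can be set beside the one seen earlier on the other core: the same change on two cores in this assay, a 2.1-fold lower number (0.32 log units; beyond the scatter) from compound 1 to compound 3 and a 1.9-fold lower number (0.27 log units; within the scatter) from compound 2 to compound 4, 1.1-fold (0.05 log units) apart, within the scatter of two such steps. For these two cores, then, the change carries over, with both steps pointing the same way and agreeing in size as closely as such measurements allow, although the new step taken alone lies within the scatter. Two cores are only two cases, so this does not show that the change would act alike on any other core, and the numbers do not say why the number falls.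

The compounds shown carry fluoro at only one place, so it remains open whether chloro, methyl or a nitrile there would give a step of similar size. On these data alone, it is also open how the number would move if an amine or a hydroxyl group stood in place of the methoxy groups of compound 2.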